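Compound 3 loses its 5-acetylfuran-2-yl group: what follows?

The source may hold more compounds than are shown below. What is called first, only, known or untested is meant among the compounds shown, and "the series" means these compounds.

For the measured compounds named here, compound 3 `CC(=O)c1ccc(CCCOc2c(C)cc(-c3noc(C(F)(F)F)n3)cc2C)o1` is the only compound here with a true number in an in vitro ADME assay on microsomes from liver (Simiiformes) (a lower number here means that the compound disappears faster, a higher number that the compound lasts longer), where compound 3 gives 1.05 h. Compound 1 `Cc1cc(-c2noc(C(F)(F)F)n2)cc(C)c1OCCCc1cc(C[S+](C)[O-])no1` reads > 2.5 h, which is a limit and not a number. Compound 2 `Cc1cc(-c2noc(C(F)(F)F)n2)cc(C)c1OCCCc1cc(CS(C)(=O)=O)no1` reads > 2.5 h, which is again only a limit. Two measured steps reach compound 3: an at least 2.3-fold lower number from compound 1 to compound 3 (0.37 log units; beyond the scatter) and an at least 2.3-fold lower number from compound 2 to compound 3 (0.37 log units; beyond the scatter). From the compounds shown here alone, their true size stays open because of the limit of > 2.5 h in this assay, at which 2 of the 3 values shown sit.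

Compound 4 `Cc1cc(-c2noc(C(F)(F)F)n2)cc(C)c1OCCCc1cccc(F)n1` keeps the shared core and changes the same place that those two steps changed: 6-fluoropyridin-2-yl in place of 5-acetylfuran-2-yl on a saturated chain carbon, three bonds along the chain from an oxygen on an aromatic ring. In words, 6-fluoropyridin-2-yl stands in place of 5-acetylfuran-2-yl on a saturated chain carbon, three bonds along the chain from an oxygen on an aromatic ring. Both steps show that the group at this place can matter in this assay, but neither contains the incoming group, so they guide the direction only weakly. Both other groups lasted longer than the group of compound 3 at 1.05 h, so a small rise is expected. The estimated step is a 1.4-fold higher number from compound 3 to compound 4 (0.15 log units; within the scatter). The expected half-life of compound 4 is 1.5 h, within an estimated range from 0.7 h to 2.5 h.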

Compound 4, half-life: > 2.5 h
Compound 4: a limit, no number (the forecaster's own chance of this, stated with the estimate: 10%); middle value at least 1.6-fold (0.22 log units) from the limit.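

In this assay, for the compounds shown here, 6-fluoropyridin-2-yl in place of 5-acetylfuran-2-yl gives an at least 2.3-fold higher number from compound 3 to compound 4 (0.37 log units; beyond the scatter), the first step at this position to a group that is neither a furan nor a 1,2-oxazole. Going by these compounds alone, the earlier compounds tied the longer half-life only to 1,2-oxazole groups carrying a sulfur side chain, whereas compound 4 has a six-membered aromatic ring with no sulfur and still lasts longer than compound 3, which now stands alone as the one compound of the four with a true number. The reading for compound 4 is itself a limit and not a number.

From the compounds shown here alone, the size of that rise stays open, and the steps from compound 1 and from compound 2 to compound 4 cannot be read, so the three longer-lasting groups cannot be ranked, for one reason: the limit of > 2.5 h in this assay, at which 3 of the 4 values shown sit. It also stays open whether the shorter half-life of compound 3 goes with its acetyl group or with its furan ring: a plain furan-2-yl and a 6-acetylpyridin-2-yl at this place would separate the two, and a plain pyridin-2-yl would show what the fluorine adds.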